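Cytotoxicity notes on compound 1 and its dimethylamino analogue

The source may report more compounds than this note shows. Statements on the series, on what has been measured and on what is new or still open speak of the compounds shown alone.

Compound 1 `O=C(NNc1c(Br)cccc1Br)c1ccc(OCC(F)(F)F)cc1` was tested in a toxicity assay on MDCK cells (Canis lupus familiaris) for cytotoxicity, read by CCK-8 assay, with a stated time of 48 h; on this read-out higher numbers stand for lower toxicity in this test and lower numbers for higher toxicity in this test. In this assay compound 1 gives only a limit, > 100000 nM. Compound 2 `CCOc1ccc(C(=O)N(C)Nc2c(Cl)cccc2Cl)cc1` likewise returns a limit in this assay, > 100000 nM. Among the measured compounds shown here, compound 3 `CCOc1ccc(C(=O)NNc2c(Br)cc(Br)cc2Br)cc1` is the one member with a number, giving 54800 nM in this assay. Compound 1 thus stands at the limit of this assay, and two of the three values shown sit there (the limit of > 100000 nM in this assay, at which 2 of the 3 values shown sit). For the measured compounds named here, no pair of measured compounds differing in one place is available, so no measured step size guides the series.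

Compound 4 `CN(C)c1ccc(C(=O)NNc2c(Br)cccc2Br)cc1` is not yet measured. It differs from compound 1 by dimethylamino in place of 2,2,2-trifluoroethoxy on an aromatic carbon; the change sits on an aromatic carbon of a six-membered aromatic ring of carbon only, para to a large group. Because compound 1 gives > 100000 nM in this assay, the step expected in this assay is a number no higher from compound 1 to compound 4 (the limit leaves the size open), within the scatter and most likely ending again at the limit. Compound 4 is estimated at 100000 nM, with a range from 40000 nM to 200000 nM.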

Compound 4, half-maximal cytotoxic concentration: > 100000 nM
Compound 4: only a limit was reported; the forecaster's own chance of this, stated with the estimate: 70%; the middle value sits exactly at the limit.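

In this assay compound 1 gives only a limit, > 100000 nM. Among the compounds shown here, compound 4 also gives only a limit, > 100000 nM, and no step between compound 1 and compound 4 can be read. The compounds shown leave open whether dimethylamino and 2,2,2-trifluoroethoxy differ at all in this assay.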